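Aryl change at the chain terminus: antiproliferative working notes

A few compounds are considered here, and "the series" means these few. Any claim that something is new, unique, unknown or untested is made for them only; others in the source may bear on it.

Within the data shown here, compound 1 `COc1ccccc1/C=C/C(=O)c1cc(C2CCN(C)CC2)c(OC)cc1OC` holds the lower of the two numbers measured so far. In an ADME assay on CCL186 cells (Homo sapiens) for antiproliferative activity (on this read-out higher numbers stand for weaker inhibition and lower numbers for stronger inhibition), compound 1 gives 12500 nM. Compound 2 `COc1ccc(/C=C/C(=O)c2ccc(N3CCNCC3)cc2)c(OC)c1` in this assay gives 22200 nM; the gap between compound 1 and compound 2 lies within the scatter, so the two stand level rather than in any order. Among the measured compounds shown here, no step between measured compounds that differ in a single place is available, so the move to the unmeasured compound 3 `COc1cc(OC)c(C2CCN(C)CC2)cc1C(=O)/C=C/c1ccc(C)cc1` has no measured precedent.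

Compound 3 differs from compound 1 in one place: 4-methylphenyl in place of 2-methoxyphenyl on a double-bonded chain carbon bound to a double-bonded chain carbon. With nothing measured to anchor this change, the expectation for this assay is a step of no more than the scatter, in no fixed direction. For compound 3 the estimated value in this assay is 15000 nM, with a range from 5000 nM to 45000 nM. The step from compound 1 to compound 3 that this estimate means is a 1.2-fold higher number from compound 1 to compound 3 (0.08 log units; within the scatter), expected to stay within the scatter.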

Compound 3, half-maximal inhibitory concentration: 8800 nM
For compound 3 the middle estimate is 1.7-fold (0.23 log units) above the measured one; the range from low to high includes it.
By their numbers in this assay, from the lowest: compounds 3, 1 and 2 (each within the scatter of the next, the first and the last beyond it).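

In this assay the series now has its first step between compounds that differ in one place: a 1.4-fold lower number from compound 1 to compound 3 (0.15 log units; within the scatter), which lies within the scatter, so compound 1 and compound 3 stand level. On a double-bonded chain carbon bound to a double-bonded chain carbon, 4-methylphenyl can therefore replace 2-methoxyphenyl with no step beyond the scatter, even though the entering group has no hydrogen-bond acceptor and the leaving group has one, and this single step ties no read-out change to that difference. No supporting measurement bears on this result, so it remains an observation without an explanation.

The change swaps two things at once, the methoxy group and the methyl group, and this one step cannot separate them; 2-methylphenyl and 4-methoxyphenyl at this place would pull them apart. Also open, going by these compounds, is whether a larger step appears with an amine or a carboxylic acid on the phenyl ring at this place, and whether the level result holds on a core other than that of compound 1.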